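This account rests on a few compounds, and the source may have more. Where it says the series, first, only, none or still open, it means among the compounds named here.

Compound 1 `COc1cc(NC(C)CCCNC(=O)NC2CCCCC2)c2ncccc2c1` and compound 2 `COc1ccc(/C(=N/NC(=O)NCCCC(C)Nc2cc(OC)cc3cccnc23)c2ccccc2)cc1` share a common core; compound 3 `COc1cc(NC(C)CCCNC(=O)NNC(=O)Nc2ccc(Cl)cc2)c2ncccc2c1` has not yet been tested. In an ADME assay on L6 cells (Rattus norvegicus) for cytotoxicity, read by resazurin assay, with a stated time of 70 h (a higher number here means a weaker inhibitor, a lower number a stronger inhibitor), compound 1 stands at "not determined" (no result reported), so no number anchors it. In this assay compound 2 returns only a limit, > 195000 nM. Among the measured compounds shown here, the single value shown thus rests at the limit of > 195000 nM in this assay, at which 1 of the 2 values shown sits. Compound 3 carries ((4-chlorophenyl)carbamoyl)amino in place of cyclohexyl on an amide-type nitrogen. With compound 1 unmeasured, no step size can be read from the data; a weak result, toward high numbers, is expected. Compound 3 is expected to give about 60000 nM in this assay, with a plausible span from 12000 nM to 250000 nM.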

Compound 3, half-maximal inhibitory concentration: 91900 nM
Beside the measured number, compound 3's estimate is 1.5-fold (0.19 log units) below it; measured number inside the range.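

No step can be read between compound 1 and compound 3: in this assay compound 1 stands at "not determined" (no result reported). The compounds shown leave open what replacing cyclohexyl with ((4-chlorophenyl)carbamoyl)amino alone does to the read-out.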